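The compounds below may be only part of what the source reports. "The series", "measured", "known", "first", "only" and "open" are said of these compounds alone.

Measured so far:
Compound 1, `CNS(=O)(=O)c1ccc(C)c(C#Cc2cc(Cl)ccc2OCC(=O)O)c1`: 10 nM
Compound 2, `O=C(O)COc1ccc(Cl)cc1C#Cc1cccc(C(F)(F)F)c1`: 92 nM
Compound 3, `CCCS(=O)(=O)c1ccc(C)c(C#Cc2cc(Cl)ccc2OC(CC)C(=O)O)c1`: 30 nM

The three compounds above were tested in an assay on CHO cells for displacement of a labelled ligand from prostaglandin D2 receptor 2 (Homo sapiens), read by scintillation counting; on this read-out lower numbers stand for stronger inhibition and higher numbers for weaker inhibition. Compound 1 gives the lowest number of the three and so shows the strongest inhibition; its gap to compound 3 lies beyond the usual scatter, and its gap to compound 2 is wider still and likewise beyond the scatter. Compound 3 and compound 2 share the shared core but carry different groups on the aryl ring and, in compound 3, a different acid side chain, so nothing can be said about any single change between them.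

Compound 4, `CCS(=O)(=O)c1ccc(C)c(C#Cc2cc(Cl)ccc2OCC(=O)O)c1`, has not yet been measured in this assay. It differs from compound 1 in one place only: ethyl in place of methylamino on a sulfonyl sulfur. Within the data shown here, no pair of measured compounds differing only in this way exists, so the size of the step is not known from the data. Compound 3, which carries a propylsulfonyl group and gives 30 nM, suggests that an alkylsulfonyl group is tolerated, though its acid side chain also differs. For compound 4 the step of a 1.6-fold higher number from compound 1 to compound 4 (0.20 log units; within the scatter) is therefore expected to be small, within the scatter or at most a modest weakening. Compound 4 is estimated at 16 nM, in the range 5 nM to 50 nM.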

Compound 4, inhibition constant: 8.6 nM
The estimate for compound 4 lay 1.9-fold (0.27 log units) above the measured number, within the range that was stated.
By their numbers in this assay, from the lowest: compounds 4 and 1 (each within the scatter of the next); then compound 3; then compound 2.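

In this assay the exchange of methylamino for ethyl on a sulfonyl sulfur reads as a 1.2-fold lower number from compound 1 to compound 4 (0.07 log units; within the scatter) and so does not separate the two groups. Among these compounds, this is the first direct comparison at this position, as the earlier compounds differ from one another in more than one place. It shows that, on the core of compound 1, the methylsulfamoyl group and its hydrogen-bond donor are not required for a number in this range, since ethylsulfonyl, with no such donor, reads the same within the scatter. Nothing in the data explains why the two groups read alike.

The compounds shown leave open how far this tolerance extends on the sulfonyl sulfur, for instance to a plain amine, a dimethylamino group or a cyclopropyl group. From the compounds shown here alone, compound 3 carries a propyl chain at this place but also differs in its acid side chain, so the effect of a longer chain alone, with the acid side chain of compound 4 kept in place, remains unknown.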